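Growing a Methyl into a 4-Methoxyphenyl Ring

The compounds below may be only part of what the source reports. "The series", "measured", "known", "first", "only" and "open" are said of these compounds alone.

Compound 1 `COc1ccc(-c2nn(-c3ccccc3F)c3c2C(c2ccc(Br)c(C)c2)CS(=O)(=O)O3)cc1`: 2.91
Compound 2 `Cc1nn(-c2ccccc2F)c2c1CCS(=O)(=O)O2`: 1.86

Of the compounds shown here, two have been measured in a physicochemical assay for lipophilicity, using the shake flask method, in phosphate buffer, measured as octanol-water partition, with a stated time of 24 h, at pH 7.4; on this read-out lower numbers stand for lower lipophilicity and higher numbers for higher lipophilicity. Compound 2 gives 1.86, the lowest of the two numbers; compound 1 gives 2.91, a gap beyond the scatter. Compound 3 `COc1ccc(-c2nn(-c3ccccc3F)c3c2CCS(=O)(=O)O3)cc1` is not yet measured. It differs from compound 2 in one place: 4-methoxyphenyl in place of methyl on an aromatic carbon. Among the measured compounds shown here, with no measured step between compounds of this kind, the expectation rests on the size of the added group alone, and a rise beyond the scatter is expected. The step from compound 2 to compound 3 is estimated as a number 0.84 log units higher from compound 2 to compound 3 (beyond the scatter). Compound 3 is therefore expected to give about 2.7, within 2.2 to 3.2.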

Compound 3, partition coefficient: 2.62
The estimate for compound 3 lay 0.08 log units above the measured number, within the range that was stated.
By their numbers in this assay, from the lowest: compound 2; then compounds 3 and 1 (each within the scatter of the next).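

In this assay, 4-methoxyphenyl in place of methyl on this aromatic carbon gives a number 0.76 log units higher from compound 2 to compound 3 (beyond the scatter), so the read-out responds to a change at this position. Hydrogen in place of 4-bromo-3-methylphenyl on the saturated ring carbon gives a number 0.29 log units lower from compound 1 to compound 3 (within the scatter), so that exchange leaves no difference that can be told from the scatter. Still open, from the compounds shown here alone, is how an amine or a carboxylic acid on the same aromatic carbon would compare with methyl and 4-methoxyphenyl. Nothing available explains the size of either step.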